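This account rests on a few compounds, and the source may have more. Where it says the series, first, only, none or still open, it means among the compounds named here.

Measured values in a functional assay on G-361 cells (Homo sapiens) for cytotoxicity, read by MTT assay, with a stated time of 3 days; a lower number here means a stronger inhibitor, a higher number a weaker inhibitor:

- Compound 1 `N#Cc1c(Cl)nc(SCc2nc3ccccc3[nH]2)nc1-c1ccccc1` gives 12.5 nM
- Compound 2 `N#Cc1c(Nc2nccs2)nc(SCc2nc3ccccc3[nH]2)nc1-c1ccccc1` gives 11.9 nM

Compound 2 stands level with compound 1, as the two numbers lie within the scatter of each other. Compound 3 `CN1CCN(c2nc(SCc3nc4ccccc4[nH]3)nc(-c3ccccc3)c2C#N)CC1` has not been measured yet. It keeps the shared core and changes one group on an aromatic carbon, with 4-methylpiperazin-1-yl in place of (1,3-thiazol-2-yl)amino (4-methylpiperazin-1-yl in place of (1,3-thiazol-2-yl)amino on an aromatic carbon). Among the compounds with values here, only one measured step bears on this carbon, where (1,3-thiazol-2-yl)amino replaced chloro: a 1.1-fold lower number from compound 1 to compound 2 (0.02 log units; within the scatter), which is within the scatter. Within the data shown here, no measured compound carries 4-methylpiperazin-1-yl, so this single step is thin evidence and the range must stay wide. Even so, no change beyond the scatter is expected, in either direction. The expected step is a 1.0-fold higher number from compound 2 to compound 3 (0.00 log units; within the scatter). Compound 3 is estimated at 12 nM, with an expected range from 5 nM to 30 nM.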

Compound 3, half-maximal inhibitory concentration: 14.7 nM
The estimate for compound 3 lay 1.2-fold (0.09 log units) below the measured number; the measured number falls inside the stated range.
By their numbers in this assay, from the lowest: compounds 2, 1 and 3 (each within the scatter of the next).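

In this assay, this aromatic carbon now carries three very different groups, and the numbers stay within the scatter, with a 1.2-fold higher number from compound 2 to compound 3 (0.09 log units; within the scatter) and a 1.2-fold higher number from compound 1 to compound 3 (0.07 log units; within the scatter). The entering 4-methylpiperazin-1-yl is a six-membered non-aromatic ring with 0 hydrogen-bond donors, while the leaving (1,3-thiazol-2-yl)amino is a five-membered aromatic ring with 1, so among these compounds neither that aromatic ring nor that donor is required to keep the number at this level. Nothing available here explains why the three groups give such similar numbers.

From the compounds shown here alone, whether this holds for a carboxylic acid or a longer alkyl chain on the same carbon remains open. Whether these groups would also stay level in other cell types is open too.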